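Sulfur side chain: ethyl for 4-methylphenyl in compound 4

This account rests on a few compounds, and the source may have more. Where it says the series, first, only, none or still open, it means among the compounds named here.

In a functional assay on MCF7 cells (Homo sapiens) for inhibition, read by MTT assay, with a stated time of 72 h (a lower number here means a stronger inhibitor, a higher number a weaker inhibitor), compound 1 `Cc1cc(Nc2cc(-c3ccccc3)[nH]n2)n2nc(SCc3ccc(F)cc3)nc2n1` gives 4020 nM, compound 2 `Cc1cc(Nc2cc(-c3ccccc3)[nH]n2)n2nc(SCc3nc4ccccc4[nH]3)nc2n1` gives 2730 nM and compound 3 `Cc1ccc(CSc2nc3nc(C)cc(Nc4cc(-c5ccccc5)[nH]n4)n3n2)cc1` gives 7290 nM. Two steps fix the place of the last value: a 1.8-fold higher number from compound 1 to compound 3 (0.26 log units; within the scatter), and a 2.7-fold higher number from compound 2 to compound 3 (0.43 log units; beyond the scatter). Only the second of these clears the scatter.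

Compound 4 `CCCSc1nc2nc(C)cc(Nc3cc(-c4ccccc4)[nH]n3)n2n1` keeps the shared core and differs only in the group on the sulfur: ethyl in place of 4-methylphenyl on a saturated chain carbon bound to a sulfur. In words, this is ethyl in place of 4-methylphenyl on a saturated chain carbon bound to a sulfur, or 4-methylbenzyl to propyl when cut one bond further out.

The measured steps that bear on this change are those at the same place: a 1.5-fold lower number from compound 1 to compound 2 (0.17 log units; within the scatter), along with the two above. They are small, and the largest is modest. All of them exchange one ring-bearing group for another, so the data hold no measured case of a chain without a ring, and the extrapolation is loose. A step beyond the scatter is therefore not expected in this assay, though a slight rise is allowed for. The expected step is a 1.2-fold higher number from compound 3 to compound 4 (0.09 log units; within the scatter). For compound 4 the estimated value is 9000 nM, with an expected range of 3500 nM to 25000 nM.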

Compound 4, half-maximal inhibitory concentration: > 50000 nM
Compound 4 was reported as a limit; the forecaster's own chance of this, stated with the estimate: 10%; middle value at least 5.5-fold (0.74 log units) away from the limit.
By their numbers in this assay, from the lowest: compounds 2, 1 and 3 (each within the scatter of the next, the first and the last beyond it). At a limit, above all of these: compound 4.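

In this assay compound 4 is reported only as a limit, not as a number: the limit of > 50000 nM in this assay, at which 1 of the 4 values shown sits.

Among the ring-bearing groups on a saturated chain carbon bound to a sulfur, no step exceeded modest size, so the earlier compounds made this position look tolerant, yet ethyl gives an at least 6.8-fold higher number from compound 3 to compound 4 (0.83 log units; beyond the scatter), an at least 12-fold higher number from compound 1 to compound 4 (1.09 log units; beyond the scatter) and an at least 18-fold higher number from compound 2 to compound 4 (1.26 log units; beyond the scatter). Every step to ethyl lies beyond the scatter, whether the group it replaces is 4-methylphenyl, 4-fluorophenyl or 1H-benzimidazol-2-yl, so within these four compounds a ring on this side chain goes with a measurable value and the ringless chain does not.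

The change removes the ring and shortens the group at once, so the compounds shown leave open which of the two carries the step, a question that a cyclohexyl group or a longer chain such as hexyl at the same place would separate. Going by these compounds, how far compound 4 lies past its limit also stays open, and the three steps therefore fix only a minimum size.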